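The source may hold more compounds than are shown below. What is called first, only, known or untested is meant among the compounds shown, and "the series" means these compounds.

Measured compounds:
compound 1 `c1cc(N2CCCC2)nc(Nc2ccc(Oc3ncnc4ccsc34)cc2)n1`: 23.2%
compound 2 `CN(c1ccc(Oc2ncnc3sccc23)cc1)c1nccc(N2CCc3ccccc3C2)n1`: 68.4%
compound 3 `c1ccc2c(c1)CCN(c1ccnc(Nc3ccc(Oc4ncnc5ccsc45)cc3)n1)C2`: 54.9%

In a functional assay on A549 cells (Homo sapiens) for inhibition, read by MTT assay, with a stated time of 72 h, tested at 20 uM (a higher number here means more inhibition at the concentration tested (going by the name of the read-out), a lower number less inhibition), compound 3 gives 54.9%, the second highest of the three numbers. Compound 2 stands closer to it with 68.4%, and compound 1 furthest away with 23.2%. Among the compounds with values here, the one step measured in one place, a number 31.7 percentage points higher from compound 1 to compound 3 (beyond the scatter), arises from 1,2,3,4-tetrahydroisoquinolin-2-yl in place of pyrrolidin-1-yl on an aromatic carbon.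

Compound 4 `CN(c1ccc(Oc2ncnc3ccsc23)cc1)c1nccc(N2CCc3ccccc3C2)n1` differs from compound 3 in one place: methyl in place of hydrogen on a nitrogen on an aromatic ring. Within the data shown here, no measured step bears directly on this change; the only measured step concerns a different group. Compound 2 also carries a methyl on that nitrogen, though on another core, and its value sits higher than that of compound 3, which is all the two values show. The expectation is therefore a small upward movement in this assay, of the size a number 7.1 percentage points higher from compound 3 to compound 4 (within the scatter), possibly within the scatter. Compound 4 is estimated at 62%, in the range 42% to 82%.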

Compound 4, a percentage reported as inhibition, at one concentration (the size of the read-out at that concentration, not a potency): 69.9%
Estimate against measurement, compound 4: 7.9 percentage points below, and the stated range covers the measured number.
By their numbers in this assay, from the lowest: compound 1; then compound 3; then compounds 2 and 4 (each within the scatter of the next).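

In this assay, within the data shown here, the methyl in place of hydrogen on a nitrogen on an aromatic ring now has a step of its own: a number 15 percentage points higher from compound 3 to compound 4 (beyond the scatter) is a modest rise, and no earlier step bore on this nitrogen. The printed step shows that, with the 1,2,3,4-tetrahydroisoquinolin-2-yl group in place, this single added carbon moves the number beyond the scatter. The exchange of the two groups of 9 heavy atoms on the oxygen on an aromatic ring gives a number 1.5 percentage points higher from compound 2 to compound 4 (within the scatter) and so stays within the scatter, which means that this pair does not tell those two groups apart in this assay.

As far as these compounds go, it remains open whether an ethyl group or a longer chain on that nitrogen would carry the number further. From the compounds shown here alone, it also remains open whether the methyl step holds with pyrrolidin-1-yl on the aromatic carbon. Nothing at hand explains the step.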